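Aryl swap at the carboxy-flanked position of the pyrazole core

The source may hold more compounds than are shown below. What is called first, only, known or untested is meant among the compounds shown, and "the series" means these compounds.

Of the compounds shown here, three have numbers so far. Compound 1 `Cc1cc(C#N)cc(-c2c(C)nn(-c3nc(-c4ccc(Cl)c(Cl)c4)c(SC(C)C)s3)c2C(=O)O)c1` gives 4800 nM in a functional assay on BJAB cells (Homo sapiens) for antiproliferative activity, with a stated time of 4 days; on this read-out higher numbers stand for an effect only at larger amounts of compound and lower numbers for an effect already at smaller amounts. Compound 2 `Cc1cccc(-c2c(C)nn(-c3nc(-c4ccc(Cl)c(Cl)c4)c(SC(C)C)s3)c2C(=O)O)c1` gives 17000 nM in this assay. Compound 3 `Cc1cc(-c2c(C)nn(-c3nc(-c4ccc(Cl)c(Cl)c4)c(SC(C)C)s3)c2C(=O)O)cc(C)n1` gives 580 nM in this assay, the lowest of the three; the nearest is an 8.3-fold lower number from compound 1 to compound 3 (0.92 log units; beyond the scatter), the furthest a 29-fold lower number from compound 2 to compound 3 (1.47 log units; beyond the scatter). Within the measured set, a 3.5-fold higher number from compound 1 to compound 2 (0.55 log units; beyond the scatter) shows the cyano group on the phenyl ring worth a modest step.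

Compound 4 `COc1cc(C#N)cc(-c2c(C)nn(-c3nc(-c4ccc(Cl)c(Cl)c4)c(SC(C)C)s3)c2C(=O)O)c1` carries 3-cyano-5-methoxyphenyl in place of 2,6-dimethylpyridin-4-yl on an aromatic carbon. Among the compounds with values here, the step bearing most directly on this change is the one from compound 1 to compound 3, since compound 4 differs from compound 1 only in a methoxy group in place of a methyl group on the phenyl ring; that step was an 8.3-fold lower number from compound 1 to compound 3 (0.92 log units; beyond the scatter). The step of a 29-fold lower number from compound 2 to compound 3 (1.47 log units; beyond the scatter) points the same way and is larger. Reversing the direction, a modest-to-large rise in this assay is therefore expected for compound 4, of about the size seen for compound 1, with the methoxy group itself an untested variable. The step from compound 3 to compound 4 is estimated as a 6.9-fold higher number from compound 3 to compound 4 (0.84 log units; beyond the scatter). Compound 4 is expected to give 4000 nM in this assay, between 1500 nM and 12000 nM.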

Compound 4, half-maximal effective concentration: 5200 nM
Compound 4: middle estimate off by 1.3-fold (0.11 log units), on the low side; the measured number falls inside the stated range.
By their numbers in this assay, from the lowest: compound 3; then compounds 1 and 4 (each within the scatter of the next); then compound 2.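

In this assay, methoxy and methyl on the nitrile-bearing phenyl ring cannot be told apart, with a 1.1-fold higher number from compound 1 to compound 4 (0.03 log units; within the scatter), so the methyl group of compound 1 can be exchanged for methoxy at this position without a step beyond the scatter. The gap to 2,6-dimethylpyridin-4-yl therefore holds for two nitrile-bearing phenyl groups, with a 9.0-fold higher number from compound 3 to compound 4 (0.95 log units; beyond the scatter), while 3-cyano-5-methoxyphenyl keeps a separation from 3-methylphenyl, with a 3.3-fold lower number from compound 2 to compound 4 (0.51 log units; beyond the scatter); the presence of a nitrile does not order the whole set, since compound 3 lacks one and has the lowest number, whereas compound 2 also lacks one and has the highest. No measurement at hand gives a reason for these steps.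

Going by these compounds, it remains open whether the low number of compound 3 follows from the ring nitrogen or from the two methyl groups, which a pyridin-4-yl group without methyl groups would help separate. On these data alone, it is also open how far the phenyl ring accepts other groups in place of methoxy, such as an amine, a fluorine atom or a longer alkoxy chain.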